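Plasma Stability of Three Measured Compounds and One Untested

This account rests on a few compounds, and the source may have more. Where it says the series, first, only, none or still open, it means among the compounds named here.

Compound 1, `CC(C)[C@H](N)C(=O)N[C@@H](CCC(=O)C=[N+]=[N-])C(=O)OCc1c[nH]c2ccccc12`, gives 10% in an ADME assay on a cell-free system (plasma, Macaca mulatta) for metabolic stability, read by LC-MS, with a stated time of 60 min, tested at 10 uM; a higher number here means that more of the compound is left, a lower number that less of the compound is left.
Compound 2, `CC(C)C[C@H](N)C(=O)N[C@@H](CCC(=O)C=[N+]=[N-])C(=O)OC(C)C`, gives 1% in this assay.
Compound 3, `CCOC(=O)[C@H](CCC(=O)C=[N+]=[N-])NC(=O)[C@@H](N)CC(C)C`, gives 1% in this assay.

Compound 1 carries the highest of the three numbers, but its distance to compound 2 and to compound 3 lies within the scatter, so no order among the three can be read. From compound 2 to compound 3 the change is hydrogen in place of methyl on a saturated chain carbon bound to an oxygen next to a carbonyl group and a saturated chain carbon, and the step is no change at the digits printed from compound 2 to compound 3 (within the scatter). How the core of compound 1 differs from the core of compound 2 is not broken down here.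

Compound 4, `CC[C@H](N)C(=O)N[C@@H](CCC(=O)C=[N+]=[N-])C(=O)OCc1c[nH]c2ccccc12`, is not yet measured. It differs from compound 1 by hydrogen in place of methyl on a saturated chain carbon bound to two saturated chain carbons. Here the place is a saturated chain carbon bound to two saturated chain carbons, whereas in the earlier pair the carbon is bound to an oxygen next to a carbonyl group and a saturated chain carbon; it is therefore the same kind of change, not the same. Because no change at the digits printed from compound 2 to compound 3 (within the scatter) showed no movement, compound 4 is expected to stay near compound 1, with an expected step of a number 2 percentage points lower from compound 1 to compound 4 (within the scatter) beside that earlier step. The estimate for compound 4 is 8%, expected between 2% and 20%.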

Compound 4, percent of the compound remaining: 4%
Compound 4: middle estimate off by 4 percentage points, on the high side, within the range that was stated.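

In this assay, trading the isopropyl group for an ethyl group, which puts hydrogen in place of methyl, gives a number 6 percentage points lower from compound 1 to compound 4 (within the scatter). Set side by side, the two cases give no sign that the core alters what this kind of change does: the same change on two cores in this assay, no change at the digits printed (within the scatter) from compound 2 to compound 3 and a number 6 percentage points lower (within the scatter) from compound 1 to compound 4, 6 percentage points apart, within the scatter of two such steps. Within the data shown here, that agreement rests on only two pairs, with the change on a different carbon in each, so it does not show that the change would behave the same way on other cores, nor does either step on its own show a real effect.

The compounds shown leave open what would happen if a longer chain, a hydroxyl group or a carboxylic acid stood on this saturated chain carbon instead of methyl or hydrogen. They also leave open whether an amide in place of the ester oxygen link would shift the percent of compound remaining beyond the usual scatter.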